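The source may report more compounds than this note shows. Statements on the series, on what has been measured and on what is new or still open speak of the compounds shown alone.

Values in a functional assay, read by spectrophotometry, with a stated time of 5 min; a higher number here means a weaker inhibitor, a lower number a stronger inhibitor:
- Compound 1 `COc1cc(/C=C/C(=O)C(=Cc2ccc(O)c(O)c2)C(=O)/C=C/c2ccc(O)c(OC)c2)ccc1O`: 10400000 nM
- Compound 2 `CCOc1ccc(C=C(C(=O)/C=C/c2ccc(O)c(OC)c2)C(=O)/C=C/c2ccc(O)c(OC)c2)cc1OCC`: 73000000 nM
- Compound 3 `CCOc1cc(/C=C/C(=O)C(=Cc2ccc(OC)c(OC)c2)C(=O)/C=C/c2ccc(O)c(OCC)c2)ccc1O`: 53200000 nM

In this assay, compound 3 at 53200000 nM lies within the scatter of compound 2, and compound 1 shows a clearly lower number. The next compound to be measured is compound 4 `CCOc1cc(/C=C/C(=O)C(=Cc2ccc(OCC)c(OCC)c2)C(=O)/C=C/c2ccc(O)c(OCC)c2)ccc1O`. It differs from compound 3 as follows: 3,4-diethoxyphenyl in place of 3,4-dimethoxyphenyl on a double-bonded chain carbon bound to a double-bonded chain carbon. In words, this is 3,4-diethoxyphenyl in place of 3,4-dimethoxyphenyl on a double-bonded chain carbon bound to a double-bonded chain carbon.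

Among the compounds with values here, the only measured step at this place is a 7.0-fold higher number from compound 1 to compound 2 (0.85 log units; beyond the scatter). That modest step starts from 3,4-dihydroxyphenyl, a group that neither compound 3 nor compound 4 carries there, so it says little about this change. More relevant, compound 2 with 3,4-diethoxyphenyl and compound 3 with 3,4-dimethoxyphenyl lie within the scatter of each other, although they also differ elsewhere. No step beyond the scatter is therefore expected in this assay.

The expected change is a 1.1-fold higher number from compound 3 to compound 4 (0.05 log units; within the scatter).

For compound 4 the estimated value is 60000000 nM, with an expected range from 25000000 nM to 130000000 nM.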

Compound 4, half-maximal inhibitory concentration: 61600000 nM
Compound 4: middle estimate off by 1.0-fold (0.01 log units), on the low side; measured number inside the range.
By their numbers in this assay, from the lowest: compound 1; then compounds 3, 4 and 2 (each within the scatter of the next).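

In this assay, 3,4-diethoxyphenyl in place of 3,4-dimethoxyphenyl on a double-bonded chain carbon bound to a double-bonded chain carbon gives a 1.2-fold higher number from compound 3 to compound 4 (0.06 log units; within the scatter), with the rest of the molecule unchanged. Within the data shown here, this is the first single-place comparison of two groups that each count no hydrogen-bond donors here, whereas the one earlier step at this place, a 7.0-fold higher number from compound 1 to compound 2 (0.85 log units; beyond the scatter), started from 3,4-dihydroxyphenyl. Between these two groups the assay therefore resolves no difference, and no measured evidence is available to explain the result.

On these data alone, it remains open whether a longer chain, such as 3,4-dipropoxyphenyl, or an amine on the aromatic ring at this place would give a step beyond the scatter. Also unresolved is whether this change would read the same with a carboxylic acid on the other arms of the shared core.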